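Moving the Dimethylamino Group on a Benzyl Arm

The source may hold more compounds than are shown below. What is called first, only, known or untested is meant among the compounds shown, and "the series" means these compounds.

Measured so far in an assay on isolated protein for inhibition of Amine oxidase [flavin-containing] A (Homo sapiens), read by fluorescence, with a stated time of 30 min; on this read-out higher numbers stand for weaker inhibition and lower numbers for stronger inhibition:
compound 1, `CCN(CCCCn1sc2cc(OC)c(OC)cc2c1=O)Cc1ccccc1N(C)C`, gives 9900 nM;
compound 2, `CCN(CCCCn1sc2cc(OC)c(OC)cc2c1=O)Cc1ccc(N(C)C)cc1`, gives 15900 nM;
compound 3, `CCN(CCCCCCn1sc2cc(OC)c(OC)cc2c1=O)Cc1ccccc1N(C)C`, gives 3400 nM.

Compound 1 and compound 2 share a core and differ by one change, (4-(dimethylamino)phenyl in place of 2-(dimethylamino)phenyl on a saturated chain carbon bound to an amine nitrogen), which produced a 1.6-fold higher number from compound 1 to compound 2 (0.21 log units; within the scatter). Compound 3 stands on a different core; how it differs from compound 1 is not broken down here, but its number in this assay is the lowest of the three, and its steps to compound 1 and compound 2 both lie beyond the scatter.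

Compound 4, `CCN(CCCCCCn1sc2cc(OC)c(OC)cc2c1=O)Cc1ccc(N(C)C)cc1`, has not yet been measured. It differs from compound 3 by 4-(dimethylamino)phenyl in place of 2-(dimethylamino)phenyl on a saturated chain carbon bound to an amine nitrogen, the same change as between compound 1 and compound 2. Because that earlier change gave a 1.6-fold higher number from compound 1 to compound 2 (0.21 log units; within the scatter), a step of similar size is expected here, a 1.6-fold higher number from compound 3 to compound 4 (0.20 log units; within the scatter). Compound 4 is therefore estimated at 5400 nM in this assay, likely between 2500 nM and 12000 nM.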

Compound 4, half-maximal inhibitory concentration: 7100 nM
The estimate for compound 4 lay 1.3-fold (0.12 log units) below the measured number, and the stated range covers the measured number.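

In this assay the change from 2-(dimethylamino)benzyl to 4-(dimethylamino)benzyl gave a 2.1-fold higher number from compound 3 to compound 4 (0.32 log units; beyond the scatter) on the core of compound 3, a modest step. Set beside the same change on the core of compound 1, the two steps cannot be told apart: the same change on two cores in this assay, a 1.6-fold higher number (0.21 log units; within the scatter) from compound 1 to compound 2 and a 2.1-fold higher number (0.32 log units; beyond the scatter) from compound 3 to compound 4, 1.3-fold (0.11 log units) apart, within the scatter of two such steps. Going by these compounds alone, this shows that the size of the step carried over between these two cores, but with only two pairs, one of them within the scatter, it shows nothing about other cores or about why the step has this size.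

The compounds shown leave open how a plain benzyl arm without the dimethylamino group would compare. They also leave open whether a longer chain than in compound 3 would keep the same step.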